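The source may report more compounds than this note shows. Statements on the series, on what has been measured and on what is new or still open speak of the compounds shown alone.

Of the compounds shown here, three have so far been measured in an assay on CHO cells for displacement of a labelled ligand from prostaglandin E2 receptor EP4 subtype (Mus musculus), read by scintillation counting; on this read-out lower numbers stand for stronger inhibition and higher numbers for weaker inhibition. Compound 1 `O=C(O)/C=C/c1ccc(Cn2cccn2)cc1OCCc1ccc2ccccc2c1` gives 670 nM. Compound 2 `O=C(O)/C=C/c1ccc(OCc2ccccc2)cc1OCCc1ccc2ccccc2c1` gives > 10000 nM, which is a limit of the assay and not a number. That outcome is the one described by the limit of > 10000 nM in this assay, at which 1 of the 3 values shown sits. Compound 3 `O=C(O)C#Cc1ccc(Cn2cccn2)cc1OCCc1ccc2ccccc2c1` gives 2900 nM and therefore stands highest of the two proper numbers, with compound 1 as its nearest neighbour; the change between them, a 4.3-fold higher number from compound 1 to compound 3 (0.64 log units; beyond the scatter), lies beyond the scatter. The other measured step, an at least 14-fold higher number from compound 1 to compound 2 (1.17 log units; beyond the scatter), concerns a different part of the shared core and is larger still.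

Compound 4 `O=C(O)COc1ccc(Cn2cccn2)cc1OCCc1ccc2ccccc2c1` has not yet been measured. It differs from compound 3 in a single place: carboxymethoxy in place of 2-carboxyethynyl on an aromatic carbon. Among the measured compounds shown here, no measured step exchanges one acid-bearing chain for another of exactly this kind, so the closest guide is a 4.3-fold higher number from compound 1 to compound 3 (0.64 log units; beyond the scatter), in which the acid chain at the same place was altered and the number moved modestly. A change of similar size, in either direction, or none beyond the scatter, is the reasonable expectation here. Compound 4 is therefore expected to give about 1500 nM, within a range from 300 nM to 8000 nM. The step this estimate implies, a 1.9-fold lower number from compound 3 to compound 4 (0.29 log units; within the scatter), is a modest one.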

Compound 4, inhibition constant: > 10000 nM
Compound 4 ended at the assay's limit (the forecaster's own chance of this, stated with the estimate: 10%); middle value at least 6.6-fold (0.82 log units) away from the limit.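

Up to this point, the chain at this position, para to a (1H-pyrazol-1-yl)methyl group, had only been exchanged between 2-carboxyethenyl and 2-carboxyethynyl, and that exchange moved the number modestly. In this assay, carboxymethoxy gives an at least 3.4-fold higher number from compound 3 to compound 4 (0.53 log units; beyond the scatter) and an at least 14-fold higher number from compound 1 to compound 4 (1.17 log units; beyond the scatter), so keeping a carboxylic acid and a chain of 5 heavy atoms at this position is not enough to hold the number. Compound 4 stands at a limit of the assay and not at a number, so the real size of both steps stays unknown, and the limit is one that a second compound in this set also reaches: the limit of > 10000 nM in this assay, at which 2 of the 4 values shown sit.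

The compounds shown leave open whether a saturated 2-carboxyethyl chain or a longer chain ending in a carboxylic acid would stay close to compound 1 with its 670 nM. They also leave open whether a carboxylic acid is needed at this position at all, a question that a primary amide or a tetrazole in its place could address.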